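Chloro on the shared core: cytotoxicity working notes

The compounds below may be only part of what the source reports. "The series", "measured", "known", "first", "only" and "open" are said of these compounds alone.

Measured compounds:
compound 1, `Cc1cc(C)cc(S(=O)(=O)n2c(SCC(=O)Nc3ccccc3Br)nc3ccccc32)c1` — >= 235000 nM
compound 2, `Cc1cc(C)cc(S(=O)(=O)n2c(SCC(=O)Nc3ccccc3Br)nc3ccc(Cl)cc32)c1` — 145000 nM
compound 3, `Cc1cc(C)cc(S(=O)(=O)n2c(SCC(=O)Nc3ccc(S(N)(=O)=O)cc3Cl)nc3ccccc32)c1` — 25600 nM

In an ADME assay on MT4 cells (Homo sapiens) for cytotoxicity (on this read-out lower numbers stand for higher toxicity in this test and higher numbers for lower toxicity in this test), compound 1 gives >= 235000 nM. That value of compound 1 is a limit of the assay, not a number (the limit of >= 235000 nM in this assay, at which 1 of the 3 values shown sits). Compound 2 gives 145000 nM in this assay. Compound 3 gives 25600 nM in this assay; this is the lowest number of the two numbers shown.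

Compound 2 differs from compound 1 by chloro in place of hydrogen on an aromatic carbon, which made an at least 1.6-fold lower number from compound 1 to compound 2 (0.20 log units; that floor lies within the scatter). The two cores differ by 2-chloro-4-sulfamoylphenyl in place of 2-bromophenyl on an amide-type nitrogen, which made an at least 9.1-fold lower number from compound 1 to compound 3 (0.96 log units; beyond the scatter).

Compound 4, `Cc1cc(C)cc(S(=O)(=O)n2c(SCC(=O)Nc3ccc(S(N)(=O)=O)cc3Cl)nc3ccc(Cl)cc32)c1`, is not yet measured. It differs from compound 3 by chloro in place of hydrogen on an aromatic carbon, the same change as from compound 1 to compound 2, at a place described in the same words.

The step from compound 3 to compound 4 is expected to be a 1.5-fold lower number from compound 3 to compound 4 (0.18 log units; within the scatter), set beside an at least 1.6-fold lower number from compound 1 to compound 2 (0.20 log units; that floor lies within the scatter); only a floor is known there, so the expectation is a small step. Compound 4 is expected to give 17000 nM in this assay, between 8000 nM and 40000 nM.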

Compound 4, half-maximal cytotoxic concentration: 23400 nM
Compound 4: the middle estimate sits 1.4-fold (0.14 log units) below what was measured, and the stated range covers the measured number.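

In this assay, chloro in place of hydrogen on an aromatic carbon gives a 1.1-fold lower number from compound 3 to compound 4 (0.04 log units; within the scatter), while 2-chloro-4-sulfamoylphenyl in place of 2-bromophenyl on an amide-type nitrogen gives a 6.2-fold lower number from compound 2 to compound 4 (0.79 log units; beyond the scatter). Carried from one core to the other, the chloro change points the same way on both, but this does not show that its size carries over: the same change on two cores in this assay, an at least 1.6-fold lower number (0.20 log units; that floor lies within the scatter) from compound 1 to compound 2 and a 1.1-fold lower number (0.04 log units; within the scatter) from compound 3 to compound 4; the limit leaves it open whether they differ. The 2-chloro-4-sulfamoylphenyl change lowers the number beyond the scatter on both cores, yet these compounds do not show that it does so by the same amount: the same change on two cores in this assay, an at least 9.1-fold lower number (0.96 log units; beyond the scatter) from compound 1 to compound 3 and a 6.2-fold lower number (0.79 log units; beyond the scatter) from compound 2 to compound 4; the limit leaves it open whether they differ.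

The compounds shown leave open whether fluoro or methoxy on the same aromatic carbon would read as chloro does in this assay. They also leave open whether the small chloro step on the core of compound 3 would hold with a carboxylic acid in place of the sulfamoyl group.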